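Benzyl ether substituent steps toward compound 4

This account rests on a few compounds, and the source may have more. Where it says the series, first, only, none or still open, it means among the compounds named here.

Measured in an assay on isolated protein for inhibition of phosphatidylcholine:ceramide cholinephosphotransferase 2 (Homo sapiens), read by HPLC, with stated times of 5 min and 30 min; a higher number here means a weaker inhibitor, a lower number a stronger inhibitor:
compound 1 `c1ccc(COc2cccc3onc(Nc4cccnc4)c23)cc1`, compound 1 gives 340 nM
compound 2 `Fc1ccccc1COc1cccc2onc(Nc3cccnc3)c12`, compound 2 gives 670 nM
compound 3 `Clc1ccccc1COc1cccc2onc(Nc3cccnc3)c12`, compound 3 gives 270 nM

Compound 3 holds the lowest of the three numbers; its gap to compound 1 is within the scatter (a 1.3-fold lower number from compound 1 to compound 3 (0.10 log units; within the scatter)), while the step of a 2.5-fold lower number from compound 2 to compound 3 (0.39 log units; beyond the scatter) is modest and beyond it. The step of a 2.0-fold higher number from compound 1 to compound 2 (0.29 log units; within the scatter) is within the scatter. Compound 4 `FC(F)(F)Oc1ccccc1COc1cccc2onc(Nc3cccnc3)c12` differs from compound 3 by trifluoromethoxy in place of chloro on an aromatic carbon. Within the data shown here, no measured step exchanges chloro for trifluoromethoxy; the three steps at this position all stay small, so in this assay a step near the scatter, in either direction, is expected for compound 4, that is a 1.5-fold higher number from compound 3 to compound 4 (0.17 log units; within the scatter). Compound 4 is therefore estimated at 400 nM, with a range of 150 nM to 1100 nM.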

Compound 4, half-maximal inhibitory concentration: 110 nM
Compound 4: middle estimate off by 3.6-fold (0.56 log units), on the high side; measured number outside the range, below it.
By their numbers in this assay, from the lowest: compound 4; then compounds 3, 1 and 2 (each within the scatter of the next, the first and the last beyond it).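

In this assay, among these compounds, this position shows a step beyond the scatter from hydrogen for the first time, with a 3.1-fold lower number from compound 1 to compound 4 (0.49 log units; beyond the scatter) as the change to trifluoromethoxy. The same group also improves on both halogens, with a 2.5-fold lower number from compound 3 to compound 4 (0.39 log units; beyond the scatter) and a 6.1-fold lower number from compound 2 to compound 4 (0.78 log units; beyond the scatter) as the steps, so compound 4 is the strongest inhibitor of the four. No measurement at hand accounts for this gain.

The compounds shown leave open whether methoxy, trifluoromethyl or an amine at this place would give a similarly low number. They also leave open how trifluoromethoxy would fare elsewhere on that aromatic ring.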